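A few compounds are considered here, and "the series" means these few. Any claim that something is new, unique, unknown or untested is made for them only; others in the source may bear on it.

Three compounds share one core, differing only in the group attached to the sulfur on the five-membered ring. Compound 1 `CCSc1nnc(Cc2ccc(Cl)cc2Oc2ccccc2Cl)[nH]1` carries an ethylsulfanyl group and gives 134% in a functional assay on the whole organism (strain NMRI) with Mus musculus as the target, with a stated time of 60 min, at a dose of 5 mg/kg by the intraperitoneal route; on this read-out lower numbers stand for a weaker effect and higher numbers for a stronger effect at the one dose given. Compound 2 `CCCSc1nnc(Cc2ccc(Cl)cc2Oc2ccccc2Cl)[nH]1` gives 118%, and compound 3 `Clc1ccc(Cc2nnc(SCc3ccccc3)[nH]2)c(Oc2ccccc2Cl)c1` gives 113%. Compound 3 has the lowest of the three numbers: the gap to compound 2 is within the scatter, while the step of a number 21 percentage points lower from compound 1 to compound 3 (beyond the scatter) lies beyond it.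

Compound 4 `CCOc1nnc(Cc2ccc(Cl)cc2Oc2ccccc2Cl)[nH]1` is not yet measured. It differs from compound 3 by ethoxy in place of benzylsulfanyl on an aromatic carbon. Among the compounds with values here, two measured steps bear on this change: a number 21 percentage points lower from compound 1 to compound 3 (beyond the scatter) and a number 5 percentage points lower from compound 2 to compound 3 (within the scatter), both showing that smaller groups at this position came with equal or higher numbers. Within the data shown here, the entering ethoxy is small, but the sulfur is also exchanged for an oxygen, and no measured pair speaks to that exchange. A rise toward the range of compound 1 is therefore expected, with wide uncertainty. For compound 4 the expected step is a number 11 percentage points higher from compound 3 to compound 4 (beyond the scatter), and the estimated value is 124%, within 100% to 148%.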

Compound 4, a percentage reported as activity, at one dose (the size of the read-out at that dose, not a potency): 120%
Compound 4: the middle estimate sits 4 percentage points above what was measured, within the range that was stated.
By their numbers in this assay, from the lowest: compounds 3, 2 and 4 (each within the scatter of the next); then compound 1.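

Keeping the ethyl chain and exchanging only the sulfur for an oxygen gives a number 14 percentage points lower from compound 1 to compound 4 (beyond the scatter) in this assay, the first direct reading of that exchange at this position. The ethoxy group, with 3 heavy atoms against 8 for benzylsulfanyl, also stands level with the larger sulfur-linked groups, at a number 7 percentage points higher from compound 3 to compound 4 (within the scatter) and a number 2 percentage points higher from compound 2 to compound 4 (within the scatter), so among these four compounds only compound 1 stands apart from the rest. Nothing available explains why this one ethylsulfanyl compound stands apart.

The compounds shown leave open whether an oxygen link would read the same with a longer chain, such as propoxy or benzyloxy. They also leave open how a nitrogen link, as in an ethylamino group, would compare with the sulfur and oxygen links.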